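The compounds below may be only part of what the source reports. "The series", "measured", "known", "first", "only" and "open" are said of these compounds alone.

Four compounds are considered here. Compound 1 `COc1ccc2c(c1)C(=O)CCN2c1nc(Cl)nc2ccccc12` and compound 2 `COc1ccc2c(c1)C(=O)CCN2c1nc(C)nc2ccccc12` share one core; compound 3 `COc1ccc2c(c1)CCCCN2c1nc(Cl)nc2ccccc12` and compound 4 `COc1ccc2c(c1)CCCCN2c1nc(C)nc2ccccc12` share another. How the core of compound 3 differs from that of compound 1 is not broken down here. In a functional assay on A549 cells (Homo sapiens) for cytotoxicity, read by sulforhodamine B assay (a lower number here means a stronger inhibitor of growth, a higher number a weaker inhibitor of growth), compound 1 gives 27 nM, compound 2 gives 24 nM and compound 3 gives 191 nM. Compound 3 stands at the highest number of the three measured, with compound 1 its nearest neighbour and compound 2 the furthest. From compound 1 to compound 2 the change is methyl in place of chloro on an aromatic carbon, and it gives a 1.1-fold lower number from compound 1 to compound 2 (0.05 log units; within the scatter). The change from compound 3 to compound 4 is methyl in place of chloro on an aromatic carbon; the surroundings of the place read the same word for word, so it is the same change made on the other core. Compound 4 is not yet measured, and the transfer rests on a single earlier pair. The step from compound 3 to compound 4 is expected to be a 1.1-fold lower number from compound 3 to compound 4 (0.05 log units; within the scatter), close to the earlier step, because the earlier change gave a 1.1-fold lower number from compound 1 to compound 2 (0.05 log units; within the scatter). Compound 4 is therefore estimated at 170 nM in this assay, expected to lie from 90 nM to 330 nM.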

Compound 4, concentration for 50% growth inhibition: 21 nM
The estimate for compound 4 lay 8.1-fold (0.91 log units) above the measured number; measured number outside the range, below it.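

In this assay, methyl in place of chloro on the other core gives a 9.1-fold lower number from compound 3 to compound 4 (0.96 log units; beyond the scatter), so on that core the change is not the silent swap it was on the core of compound 1. The change therefore did not carry over from one core to the other at the same size, and in this series its effect cannot be read across cores from a single pair: the same change on two cores in this assay, a 1.1-fold lower number (0.05 log units; within the scatter) from compound 1 to compound 2 and a 9.1-fold lower number (0.96 log units; beyond the scatter) from compound 3 to compound 4, 8.1-fold (0.91 log units) apart, beyond the scatter of two such steps This shows that the size of the step depends on the core for these four compounds, but it does not show which feature of the two cores is responsible, and with one pair per core it gives no rule for any further core.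

On these data alone, whether other groups at the same place between two ring nitrogen atoms, such as an amine, a methoxy group or a longer alkyl chain, would also separate the two cores remains open. Also open, as far as these compounds go, is whether the gap follows chloro or methyl specifically, as only these two groups appear at that place.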